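The source may hold more compounds than are shown below. What is called first, only, known or untested is meant among the compounds shown, and "the series" means these compounds.

Measured so far in a physicochemical assay for solubility, with a stated time of 24 h, tested at 30 mg/mL; on this read-out higher numbers stand for higher solubility and lower numbers for lower solubility:
compound 1 `O=C(CCCCCNc1c(Nc2ccccc2)c(=O)c1=O)NO` gives 2200000 nM
compound 2 `COc1ccc(Nc2c(NCCCCCC(=O)NO)c(=O)c2=O)cc1` gives 300000 nM

Compound 2 has the lower of these two numbers, and compound 1 stands above it by a step beyond the scatter. Compound 3 `O=C(CCCCCNc1c(Nc2ccc(C(F)(F)F)cc2)c(=O)c1=O)NO` differs from compound 2 in one place (trifluoromethyl in place of methoxy on an aromatic carbon), with trifluoromethyl in place of methoxy on an aromatic carbon. Among the measured compounds shown here, the only measured step at that place is a 7.3-fold lower number from compound 1 to compound 2 (0.87 log units; beyond the scatter) and it is modest, with methoxy in place of hydrogen. For the measured compounds named here, no measured compound carries trifluoromethyl yet, so a smaller step toward a lower number is expected in this assay here. The expected step is a 2.0-fold lower number from compound 2 to compound 3 (0.30 log units; within the scatter) for now. For compound 3 the estimated value is 150000 nM with a likely range from 30000 nM to 700000 nM as an expectation only.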

Compound 3, solubility: 4700000 nM
Beside the measured number, compound 3's estimate is 31-fold (1.50 log units) below it, and the stated range ends below it.
By their numbers in this assay, from the lowest: compound 2; then compound 1; then compound 3.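

In this assay, a group on this aromatic carbon, para to a large group, need not lower the number: trifluoromethyl sits far above methoxy (a 16-fold higher number from compound 2 to compound 3 (1.19 log units; beyond the scatter)) and also above hydrogen (a 2.1-fold higher number from compound 1 to compound 3 (0.33 log units; beyond the scatter)). Methoxy and trifluoromethyl therefore move the number in opposite directions from hydrogen, so the outcome here depends on which group is attached. Nothing available gives a reason for this difference. Only these three groups have been compared at this place. On these data alone, how a chlorine atom, a nitrile or an amine would behave there remains open.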